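This account rests on a few compounds, and the source may have more. Where it says the series, first, only, none or still open, it means among the compounds named here.

Compound 1 `O=[N+]([O-])c1ccc(N/C(=N\O)c2ccc(F)cc2)c2nonc12`: in an assay on isolated protein for inhibition of Indoleamine 2,3-dioxygenase 1 (Homo sapiens), read by spectrophotometry, with a stated time of 1 h (a lower number here means a stronger inhibitor, a higher number a weaker inhibitor), compound 1 gives 100 nM
Compound 2 `O=[N+]([O-])c1ccc(N/C(=N\O)c2ccc(Br)cc2)c2nonc12`: in this assay compound 2 gives 117 nM

Of the two numbers, compound 2 holds the upper one, with compound 1 nearest; the step of a 1.2-fold higher number from compound 1 to compound 2 (0.07 log units; within the scatter) lies within the scatter, so the two are not separable. Compound 3 `O=[N+]([O-])c1ccc(N/C(=N\O)c2ccc(F)c(Br)c2)c2nonc12` differs from compound 2 by 3-bromo-4-fluorophenyl in place of 4-bromophenyl on a carbon with a double bond to nitrogen. Among the compounds with values here, the only measured step that bears on this change is the halogen swap on the same ring, which moved the number within the scatter. No step beyond the scatter is therefore expected in this assay, in either direction. Compound 3 is estimated at 120 nM (50 nM to 300 nM), the expected step being a 1.0-fold higher number from compound 2 to compound 3 (0.01 log units; within the scatter).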

Compound 3, half-maximal inhibitory concentration: 92 nM
Compound 3: middle estimate off by 1.3-fold (0.12 log units), on the high side, and the stated range covers the measured number.
By their numbers in this assay, from the lowest: compounds 3, 1 and 2 (each within the scatter of the next).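

In this assay, the phenyl ring on the carbon with a double bond to nitrogen carries two halogens as readily as one: 3-bromo-4-fluorophenyl in place of 4-bromophenyl gives a 1.3-fold lower number from compound 2 to compound 3 (0.10 log units; within the scatter), and bromo in place of hydrogen gives a 1.1-fold lower number from compound 1 to compound 3 (0.04 log units; within the scatter). Neither step separates the compounds, so the three halogen patterns cannot be ranked. No measurement at hand accounts for this flat result. On these data alone, whether an amine or a carboxylic acid on this ring would move the number beyond the scatter stays open. So does the outcome of replacing the ring with a longer alkyl chain.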